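From pentan-3-yl to cyclopropyl on a shared core

A few compounds are considered here, and "the series" means these few. Any claim that something is new, unique, unknown or untested is made for them only; others in the source may bear on it.

In a physicochemical assay for solubility, measured as kinetic solubility, at pH 2 (on this read-out higher numbers stand for higher solubility and lower numbers for lower solubility), compound 1 (`CC(C)[C@@H](c1ccc(-c2ccc3cccc(F)c3c2)[nH]c1=O)[C@@H]1OC(=O)NC1=O`) gives 6900 nM and compound 2 (`CC(C)C(c1ccc(-c2ccc3cccc(F)c3c2)[nH]c1=O)C1NC(=O)NC1=O`) gives 5800 nM while compound 3 (`CCC(CC)C(/C=C1\OC(=O)NC1=O)c1ccc(-c2ccc3cccc(F)c3c2)[nH]c1=O`) gives 3680 nM on the same read-out. Compound 3 therefore stands level with both others, its gaps to them lying within the scatter. Compound 4 (`O=C1NC(=O)/C(=C/C(c2ccc(-c3ccc4cccc(F)c4c3)[nH]c2=O)C2CC2)O1`) carries cyclopropyl in place of pentan-3-yl on a saturated chain carbon bound to an aromatic carbon and a double-bonded chain carbon. For the measured compounds named here, no measured pair shows this change, so only a slight upward step is expected in this assay here. The estimated change a 1.4-fold higher number from compound 3 to compound 4 (0.13 log units; within the scatter) stays within the scatter. For compound 4 the expected value is 5000 nM with 2200 nM and 11000 nM as the estimated ends of the range.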

Compound 4, solubility: 3850 nM
Compound 4: middle estimate off by 1.3-fold (0.11 log units), on the high side; the measured number falls inside the stated range.
By their numbers in this assay, from the lowest: compounds 3, 4, 2 and 1 (each within the scatter of the next).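

At this saturated chain carbon, bound to an aromatic carbon and a double-bonded chain carbon, cyclopropyl in place of pentan-3-yl gives a 1.0-fold higher number from compound 3 to compound 4 (0.02 log units; within the scatter) in this assay and so leaves the two compounds level. For the compounds shown here, this single exchange, the first step that can be read here, thus shows that the read-out does not separate these two groups at this position. No measurement offered here accounts for this result.

Still open, as far as these compounds go, is whether an amine or a carboxylic acid on this carbon would move the number beyond the scatter.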